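The source may hold more compounds than are shown below. What is called first, only, known or untested is meant among the compounds shown, and "the series" means these compounds.

Measured compounds:
compound 1, `O=C(Nn1c(-c2cccc([N+](=O)[O-])c2)nc2c(-c3ccco3)n[nH]c2c1=O)c1ccccc1` — 21.2%
compound 2, `COc1cccc(-c2nc3c(-c4ccco4)n[nH]c3c(=O)n2NC(=O)c2ccccc2)c1` — 49.8%
compound 3, `O=C(Nn1c(-c2ccccc2)nc2c(-c3ccc(Cl)cc3)n[nH]c2c1=O)c1ccccc1` — 92%

In a functional assay on HT-29 cells (Homo sapiens) for cytotoxicity, read by sulforhodamine B assay, with a stated time of 2 days, tested at 100 uM (a higher number here means more inhibition at the concentration tested (going by the name of the read-out), a lower number less inhibition), compound 3 stands highest of the three numbers; compound 2 lies beyond the scatter below it, compound 1 further still. For the measured compounds named here, the one step between compounds differing in a single place is a number 28.6 percentage points higher from compound 1 to compound 2 (beyond the scatter); compound 3 differs from both in more than one place, so only its value, not a step, can be set against them.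

Compound 4, `CCCCCc1nc2c(-c3ccc(Cl)cc3)n[nH]c2c(=O)n1NC(=O)c1ccccc1`, is not yet measured. It differs from compound 3 as follows: pentyl in place of phenyl on an aromatic carbon. Going by the values given here, no measured step bears on a phenyl-to-pentyl change at this position, nor on any chain in place of a ring; the only step on hand concerns a substituent on that phenyl and is modest. The expectation for this assay therefore rests mainly on compound 3 keeping most of its inhibition, with a wide margin for a drop. The step of a number 32 percentage points lower from compound 3 to compound 4 (beyond the scatter) is estimated as a moderate decline. Compound 4 is expected to give 60%, in the range 25% to 90%.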

Compound 4, a percentage reported as inhibition, at one concentration (the size of the read-out at that concentration, not a potency): 90.1%
Beside the measured number, compound 4's estimate is 30.1 percentage points below it; the whole stated range lies below it.
By their numbers in this assay, from the lowest: compound 1; then compound 2; then compounds 4 and 3 (each within the scatter of the next).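

In this assay pentyl in place of phenyl on the aromatic carbon between two ring nitrogen atoms gives a number 1.9 percentage points lower from compound 3 to compound 4 (within the scatter) with the rest of the structure unchanged. The earlier compounds shown here all carry an aromatic ring at this place, so they could not show that an open chain can stand there. In this pair, then, the read-out does not depend on an aromatic ring at this position. Nothing on hand accounts for this result.

On these data alone, whether a methyl group, a longer chain such as octyl, or a chain ending in an amine or a carboxylic acid would fit this position equally well stays open. As far as these compounds go, it is also open whether pentyl would give the same result on a core carrying the furan ring of compounds 1 and 2 instead of the chlorophenyl group.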